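The source may hold more compounds than are shown below. What is called first, only, known or untested is meant among the compounds shown, and "the series" means these compounds.

Measured compounds in a functional assay on 786-0 cells (Homo sapiens) for inhibition, read by sulforhodamine B assay, with a stated time of 48 h; on this read-out lower numbers stand for higher toxicity in this test and higher numbers for lower toxicity in this test:
Compound 1 `O=C(Nc1cccc(-n2cc(-c3ccncc3)c(-c3ccc(Cl)c(O)c3)n2)c1)Nc1cccc(C(F)(F)F)c1` gives > 32500 nM, which is a limit of the assay and not a number.
Compound 2 `COc1cc(-c2nn(-c3cccc(NC(=O)Nc4cc(C(F)(F)F)cc(C(F)(F)F)c4)c3)cc2-c2ccncc2)ccc1Cl` gives 4310 nM.
Compound 3 `COc1cc(-c2nn(-c3cccc(NC(=O)Nc4cccc(C(F)(F)F)c4)c3)cc2-c2ccncc2)ccc1Cl` gives > 50000 nM, again a limit of the assay rather than a number.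

Within the data shown here, compound 2 therefore stands as the only compound with a number in this assay; the two other values sit at limits. Compound 4 `O=C(Nc1cccc(-n2cc(-c3ccncc3)c(-c3ccc(Cl)c(O)c3)n2)c1)Nc1cc(C(F)(F)F)cc(C(F)(F)F)c1` differs from compound 2 by hydrogen in place of methyl on an oxygen on an aromatic ring, that is methoxy to hydroxy, 4-chloro-3-methoxyphenyl to 4-chloro-3-hydroxyphenyl. Among the measured compounds shown here, the one measured step at this same place, a step that the two limits leave unreadable from compound 1 to compound 3, runs between two limits, the limit of > 32500 nM in this assay, at which 1 of the 3 values shown sits, and (the limit of > 50000 nM in this assay, at which 1 of the 3 values shown sits), and so shows neither size nor direction. The other measured step, an at least 11-fold higher number from compound 2 to compound 3 (1.06 log units; beyond the scatter), concerns the trifluoromethyl groups, which compound 4 keeps exactly as compound 2 has them, so it does not bear on this change. With no readable step at this place, no shift beyond the scatter is expected, though the expectation rests on thin ground. Compound 4 is estimated at 5000 nM, within a range from 1500 nM to 20000 nM. The expected change is a 1.2-fold higher number from compound 2 to compound 4 (0.06 log units; within the scatter).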

Compound 4, concentration lethal to 50% of the cells: 18000 nM
Compound 4: the middle estimate sits 3.6-fold (0.56 log units) below what was measured; measured number inside the range.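

In this assay, among these compounds, the change from methoxy to hydroxy on the 4-chloro-3-methoxyphenyl group now has a readable size and direction, which the earlier compounds did not give: a 4.2-fold higher number from compound 2 to compound 4 (0.62 log units; beyond the scatter), a modest step towards lower toxicity in this test. The trifluoromethyl change can now also be read on the hydroxy side as an at least 1.8-fold lower number from compound 1 to compound 4 (0.25 log units; that floor lies within the scatter), though that floor alone does not establish a step beyond the scatter. The change can thus be set beside its counterpart on the methoxy side: the same change on two cores in this assay, an at least 11-fold higher number (1.06 log units; beyond the scatter) from compound 2 to compound 3 and an at least 1.8-fold higher number (0.25 log units; that floor lies within the scatter) from compound 4 to compound 1; the limit leaves it open whether they differ.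

Going by these compounds, compound 1 and compound 3 both stand at limits of the assay, so the step between them cannot be read and the effect of the hydroxy change with a single trifluoromethyl group stays open. On these data alone, how an amine or an ethoxy group would read at this place also stays open.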